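Pyrazolyl to pyrazolinone swap on the shared thienopyrimidinone core

A few compounds are considered here, and "the series" means these few. Any claim that something is new, unique, unknown or untested is made for them only; others in the source may bear on it.

Measured compounds:
compound 1 `Cc1c(C(N)=O)sc2nc(NN)n(Cc3ccccc3)c(=O)c12`: 43%
compound 2 `Cc1cc(C)n(-c2nc3sc(C(N)=O)c(C)c3c(=O)n2Cc2ccccc2)n1`: 32%

In a functional assay on the whole organism (strain albino) for inhibition, with Rattus norvegicus as the target, read by paw edema, in the formalin test, with a stated time of 1 h, at a dose of 10 mg/kg by the oral route (a higher number here means more inhibition at the dose given (going by the name of the read-out), a lower number less inhibition), compound 2 gives the lowest of the two numbers; the nearest is compound 1, and the step of a number 11 percentage points lower from compound 1 to compound 2 (beyond the scatter) lies beyond the scatter. Compound 3 `CC1=NN(c2nc3sc(C(N)=O)c(C)c3c(=O)n2Cc2ccccc2)C(=O)C1` is not yet measured. It differs from compound 2 as follows: a group of 7 heavy atoms (4 carbon, 2 nitrogen, 1 oxygen; one five-membered non-aromatic ring with 2 hetero atoms) in place of a group of 7 heavy atoms (5 carbon, 2 nitrogen; one five-membered aromatic ring with 2 hetero atoms), on an aromatic carbon. Among the compounds with values here, no measured step bears on this change; the single step from compound 1 to compound 2 concerns a different group at the same place. A step within the scatter, in no firm direction, is therefore expected, written as a number 1 percentage points higher from compound 2 to compound 3 (within the scatter). Compound 3 is expected to give 33%, within 18% to 48%.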

Compound 3, a percentage reported as inhibition, in the whole organism at one dose (the size of the read-out at that dose, not a potency): 34%
The estimate for compound 3 lay 1 percentage points below the measured number, within the range that was stated.
By their numbers in this assay, from the lowest: compounds 2, 3 and 1 (each within the scatter of the next, the first and the last beyond it).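

In this assay, the move from an aromatic to a non-aromatic five-membered ring at this position gives a number 2 percentage points higher from compound 2 to compound 3 (within the scatter), so the two ring groups cannot be told apart. The aminoamino group of compound 1 is also not clearly separated from the new ring, with a number 9 percentage points lower from compound 1 to compound 3 (within the scatter), so the earlier gap holds only for the 3,5-dimethyl-1H-pyrazol-1-yl group. No measured evidence accounts for these results. Open, from the compounds shown here alone, is how a morpholine ring or a simple methylamino group at this position would compare, and whether these readings at a single dose would hold at other doses.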